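Piperidinyl crotonamide variant of compound 2 in MCF7 cells

A few compounds are considered here, and "the series" means these few. Any claim that something is new, unique, unknown or untested is made for them only; others in the source may bear on it.

Among the three compounds measured in a functional assay on MCF7 cells (Homo sapiens) for antiproliferative activity, read by MTT assay, with a stated time of 72 h (on this read-out lower numbers stand for stronger inhibition and higher numbers for weaker inhibition), compound 2 `CCC/C=C/C(=O)Nc1cc2c(N3CCCc4ccccc43)ncnc2cc1OC` gives 1210 nM, the lowest number of the set: compound 1 `CCC/C=C/C(=O)Nc1cc2c(N3CCc4ccccc43)ncnc2cc1OC` gives 3160 nM, a step of a 2.6-fold lower number from compound 1 to compound 2 (0.42 log units; beyond the scatter), and compound 3 `CCC/C=C/C(=O)Nc1cc2c(N3CCCc4ccccc43)ncnc2cc1O[C@@H]1CCOC1` gives 4230 nM, a step of a 3.5-fold higher number from compound 2 to compound 3 (0.54 log units; beyond the scatter). Compound 4 `COc1cc2ncnc(N3CCCc4ccccc43)c2cc1NC(=O)/C=C/CN1CCCCC1` differs from compound 2 by piperidin-1-yl in place of ethyl on a saturated chain carbon bound to a double-bonded chain carbon. Neither measured step touches this part of the molecule; both concern the other end of the shared core, so they do not bear on the change. Within the data shown here, with no direct precedent, the step from compound 2 to compound 4 is expected to be small, a 1.9-fold lower number from compound 2 to compound 4 (0.27 log units; within the scatter), towards a lower number in this assay. Compound 4 is therefore estimated at 650 nM, within a range of 150 nM to 2800 nM.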

Compound 4, half-maximal inhibitory concentration: 3930 nM
Compound 4: the middle estimate sits 6.0-fold (0.78 log units) below what was measured; the measured number lies above the stated range.
By their numbers in this assay, from the lowest: compound 2; then compounds 1, 4 and 3 (each within the scatter of the next).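

In this assay, piperidin-1-yl in place of ethyl on a saturated chain carbon bound to a double-bonded chain carbon gives a 3.2-fold higher number from compound 2 to compound 4 (0.51 log units; beyond the scatter) and so shows that this place on the chain is not indifferent to change. The larger group, which brings a ring and a nitrogen, moves the number upward, and compound 2 keeps the lowest value of the set. Nothing available accounts for this step. The compounds shown leave open whether the ring or the nitrogen goes with the higher number. A cyclohexyl group or a dimethylamino group at the same place would separate the two.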